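Urea aryl swap: from fluorine to two methyls

The source may hold more compounds than are shown below. What is called first, only, known or untested is meant among the compounds shown, and "the series" means these compounds.

Compound 2 `O=C(Nc1cccc(CNc2nccnc2Cl)c1)Nc1ccccc1F` carries a shared core seen also in compound 1 `O=C(Nc1ccccc1)Nc1cccc(CNc2nccnc2Cl)c1` and compound 3 `CC(C)(C)c1ccc(NC(=O)Nc2cccc(CNc3nccnc3Cl)c2)cc1`. In a functional assay on HepG2 cells (Homo sapiens) for antiproliferative activity, read by MTT assay, with a stated time of 48 h (a lower number here means a stronger inhibitor, a higher number a weaker inhibitor), compound 2 gives 10500 nM, the second highest of the three numbers: compound 1 gives 15600 nM and compound 3 gives 7550 nM, both within the scatter of compound 2. The change to compound 4 `Cc1ccc(NC(=O)Nc2cccc(CNc3nccnc3Cl)c2)c(C)c1` is 2,4-dimethylphenyl in place of 2-fluorophenyl on an amide-type nitrogen. Within the data shown here, two measured steps bear on it: a 1.5-fold lower number from compound 1 to compound 2 (0.17 log units; within the scatter), and a 2.1-fold lower number from compound 1 to compound 3 (0.32 log units; beyond the scatter), where an alkyl group on the same ring gave a modest gain. A modest lowering is therefore expected for compound 4, as a 1.9-fold lower number from compound 2 to compound 4 (0.28 log units; within the scatter). In this assay compound 4 is estimated at 5500 nM, with a range from 2500 nM to 12000 nM.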

Compound 4, half-maximal inhibitory concentration: 9290 nM
For compound 4 the middle estimate is 1.7-fold (0.23 log units) below the measured one; low and high end bracket the measured number.
By their numbers in this assay, from the lowest: compounds 3, 4, 2 and 1 (each within the scatter of the next, the first and the last beyond it).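

In this assay, 2,4-dimethylphenyl in place of 2-fluorophenyl on an amide-type nitrogen gives a 1.1-fold lower number from compound 2 to compound 4 (0.05 log units; within the scatter) and the same group in place of phenyl gives a 1.7-fold lower number from compound 1 to compound 4 (0.23 log units; within the scatter), so at this position the two methyl groups leave the number within the scatter of both. Among the steps from compound 1, only the tert-butyl change stays beyond the scatter, with a 2.1-fold lower number from compound 1 to compound 3 (0.32 log units; beyond the scatter). No measurement at hand accounts for this result.

As far as these compounds go, it remains open whether an aryl group carrying an amine or a carboxylic acid would shift the number further in this assay. From the compounds shown here alone, it is equally open whether a longer alkyl chain on the ring would do so.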